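Removing tert-butoxycarbonyl in a series at the assay limit

The source may report more compounds than this note shows. Statements on the series, on what has been measured and on what is new or still open speak of the compounds shown alone.

Compound 1 `CC(C)[C@H](NC(=O)c1cc(Cl)ccc1OCCN)C(=O)Nc1ccc([N+](=O)[O-])cc1Cl` gives > 10000 nM
Compound 2 `C[C@H](NC(=O)c1cc(Cl)ccc1OCCN)C(=O)Nc1ccc([N+](=O)[O-])cc1Cl` gives > 10000 nM
Compound 3 `CSCC[C@H](NC(=O)c1cc(Cl)ccc1OCCNC(=O)OC(C)(C)C)C(=O)Nc1ccc([N+](=O)[O-])cc1Cl` gives > 10000 nM

In a functional assay on MCF7 cells (Homo sapiens) for inhibition, read by MTT assay, with a stated time of 72 h (on this read-out lower numbers stand for stronger inhibition and higher numbers for weaker inhibition), compound 3 stands at > 10000 nM, which is a limit and not a number. The other two compounds offer no number either, as the evidence shows (the limit of > 10000 nM in this assay, at which 3 of the 3 values shown sit).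

Compound 4 `CSCC[C@H](NC(=O)c1cc(Cl)ccc1OCCN)C(=O)Nc1ccc([N+](=O)[O-])cc1Cl` is not yet measured. It follows from compound 3 by hydrogen in place of tert-butoxycarbonyl on an amine nitrogen, leaving a 2-aminoethyl group. Among the compounds with values here, no measured step covers this change. Within the data shown here, the only step is a step that the two limits leave unreadable from compound 1 to compound 2, so no size can be carried over from it.

Compound 1 also carries 2-aminoethyl and gives > 10000 nM, a limit. Compound 2 also carries 2-aminoethyl and gives > 10000 nM, again a limit.

On that basis no readable gain is expected in this assay, and a further limit is the likeliest report. The expected change is a step that the limit leaves unreadable from compound 3 to compound 4 in size. For compound 4 the estimate is 14000 nM, with an expected range from 5000 nM to 40000 nM.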

Compound 4, half-maximal inhibitory concentration: > 10000 nM
Compound 4: only a limit was reported; the forecaster's own chance of this, stated with the estimate: 80%; the middle value lies beyond the limit too.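

In this assay compound 4 gives > 10000 nM, a limit and not a number. Its steps from compound 1, compound 2 and compound 3 cannot be read: the limit of > 10000 nM in this assay, at which 4 of the 4 values shown sit.

The compounds shown leave open how far beyond the limit each lies, and whether any change to the shared core gives a readable value in this assay.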